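Lengthening the chloroalkyl chain of compound 2

This account rests on a few compounds, and the source may have more. Where it says the series, first, only, none or still open, it means among the compounds named here.

In a functional assay on MGC-803 cells (Homo sapiens) for inhibition, read by MTT assay, with a stated time of 48 h (on this read-out lower numbers stand for stronger inhibition and higher numbers for weaker inhibition), compound 1 `C#CC(=O)N(Cc1ccc(OC)c(O)c1)c1cc(OC)c(OC)c(OC)c1` gives 170 nM and compound 2 `COc1ccc(CN(C(=O)CCCl)c2cc(OC)c(OC)c(OC)c2)cc1O` gives 140 nM, so compound 2 stands level with compound 1 within the scatter. Compound 3 `COc1ccc(CN(C(=O)CCCCCl)c2cc(OC)c(OC)c(OC)c2)cc1O` has not been measured. Its difference from compound 2 is 2-chloroethyl in place of chloro on a saturated chain carbon, two bonds along the chain from a carbonyl carbon. Within the data shown here, only one measured step bears on this, and only loosely: a 1.2-fold lower number from compound 1 to compound 2 (0.08 log units; within the scatter), with 2-chloroethyl in place of ethynyl on a carbonyl carbon, lies within the scatter. Among the measured compounds shown here, no measured step extends a chain, so the evidence is thin. No shift beyond the scatter is therefore expected in this assay. The expected step, a 1.3-fold higher number from compound 2 to compound 3 (0.11 log units; within the scatter), stays within the scatter. For compound 3 the estimated value is 180 nM, with an expected range of 70 nM to 500 nM.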

Compound 3, half-maximal inhibitory concentration: 540 nM
Estimate against measurement, compound 3: 3.0-fold (0.48 log units) below, and the stated range ends below it.
By their numbers in this assay, from the lowest: compounds 2 and 1 (each within the scatter of the next); then compound 3.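

In this assay, among these compounds, the acyl chain on the carbonyl carbon is the first place where a change moves the number beyond the scatter: the step is a 3.9-fold higher number from compound 2 to compound 3 (0.59 log units; beyond the scatter), with 2-chloroethyl in place of chloro on a saturated chain carbon, two bonds along the chain from a carbonyl carbon. Against the other neighbour the result is similar, a 3.2-fold higher number from compound 1 to compound 3 (0.50 log units; beyond the scatter), with 4-chlorobutyl in place of ethynyl on a carbonyl carbon, so this position does not accept every group alike, whereas the 2-chloroethyl and ethynyl compounds stood level. Nothing at hand accounts for this rise.

The three compounds leave open whether a longer chain such as 5-chloropentyl carries the rise further, and how 3-chloropropyl on the carbonyl carbon would read. A plain butyl group in place of 4-chlorobutyl would show whether the chlorine has any part in the shift.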